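This account rests on a few compounds, and the source may have more. Where it says the series, first, only, none or still open, it means among the compounds named here.

Compound 1 `COc1cc[nH]c1/C=C1\C(=O)Nc2ccc(F)c(C#C[C@H](C)O)c21` is the starting point of this account. For the measured compounds named here, in a functional assay on MDA-MB-435 cells (Homo sapiens) for inhibition (on this read-out lower numbers stand for stronger inhibition and higher numbers for weaker inhibition), compound 1 gives 190 nM, the lowest of the three numbers measured so far. Compound 3 `COc1cc[nH]c1/C=C1\C(=O)Nc2ccc(F)c(C#C[C@@H](N)[C@@H](C)O)c21` carries 1-amino-2-hydroxypropyl in place of 1-hydroxyethyl on a triple-bonded carbon; in this assay compound 3 gives 300 nM, and the step of a 1.6-fold higher number from compound 1 to compound 3 (0.20 log units; within the scatter) stays within the scatter. Compound 2 `COc1cc[nH]c1/C=C1\C(=O)Nc2ccc(F)c(C#C[C@H](CO)NCCO)c21` carries 2-hydroxy-1-((2-hydroxyethyl)amino)ethyl on that carbon; in this assay compound 2 gives 1270 nM, and the step of a 6.7-fold higher number from compound 1 to compound 2 (0.83 log units; beyond the scatter) is the only one beyond the scatter, as is the return step a 4.2-fold lower number from compound 2 to compound 3 (0.63 log units; beyond the scatter).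

Compound 4 `COc1cc[nH]c1/C=C1\C(=O)Nc2ccc(F)c(C#C[C@@H]3CCCN3)c21` differs from compound 1 in this way: pyrrolidin-2-yl in place of 1-hydroxyethyl on a triple-bonded carbon. The change keeps one hydrogen-bond donor and one acceptor but replaces the hydroxyl with a ring nitrogen. The step from compound 1 to compound 3 shows that a nitrogen on this side chain, with the hydroxyl still present, is tolerated, whereas the larger group of compound 2 costs a modest amount. Compound 4 sits between these cases, so a small rise is expected, a 1.6-fold higher number from compound 1 to compound 4 (0.20 log units; within the scatter), likely within or near the scatter. Compound 4 is therefore estimated at 300 nM, in the range 120 nM to 800 nM.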

Compound 4, half-maximal inhibitory concentration: 31 nM
For compound 4 the middle estimate is 9.7-fold (0.99 log units) above the measured one; the whole stated range lies above it.
By their numbers in this assay, from the lowest: compound 4; then compounds 1 and 3 (each within the scatter of the next); then compound 2.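

In this assay, for the compounds shown here, the pyrrolidin-2-yl group on the triple-bonded carbon gives the only step downward from compound 1, a 6.1-fold lower number from compound 1 to compound 4 (0.79 log units; beyond the scatter), and it also stands clear of the two open-chain amines, with a 9.7-fold lower number from compound 3 to compound 4 (0.99 log units; beyond the scatter) and a 41-fold lower number from compound 2 to compound 4 (1.61 log units; beyond the scatter) in this series. Until now no side chain with a nitrogen had fallen below compound 1, so a nitrogen at this place can go with a clear gain in inhibition, although compound 2 and compound 3 show that it does not always do so. Nothing measured here explains why the ring form stands apart from the open chains.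

The compounds shown do not separate the effect of the ring from that of the nitrogen, since an open-chain 1-aminoethyl group would carry the nitrogen without the ring and a cyclopentyl group would carry the ring without the nitrogen. As far as these compounds go, it also remains open how a six-membered piperidin-2-yl ring, a methyl group on the pyrrolidine nitrogen or the opposite configuration at the defined stereocentre would read in this assay on this same core.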